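The source may hold more compounds than are shown below. What is called first, only, known or untested is meant among the compounds shown, and "the series" means these compounds.

Three analogues on a shared core have been measured in an assay on isolated protein for inhibition of Amine oxidase [flavin-containing] B (Homo sapiens), read by fluorescence, with a stated time of 20 min; a lower number here means a stronger inhibitor, a higher number a weaker inhibitor. Compound 1 `CC/C(C)=N\Nc1nc(-c2cccc([N+](=O)[O-])c2)cs1` gives 351 nM. Compound 2 `C=CCC/C(C)=N\Nc1nc(-c2cccc([N+](=O)[O-])c2)cs1` gives 101 nM, and compound 3 `CCCC/C(C)=N\Nc1nc(-c2cccc([N+](=O)[O-])c2)cs1` gives 118 nM. Compound 3 thus stands second highest of the three numbers, close to compound 2 and clearly apart from compound 1. Compound 4 `CCCCCC/C(C)=N\Nc1nc(-c2cccc([N+](=O)[O-])c2)cs1` has not yet been measured; it differs from compound 3 by ethyl in place of hydrogen on a saturated chain carbon, four bonds along the chain from a carbon with a double bond to nitrogen. For the measured compounds named here, two measured steps bear on lengthening this chain: a 3.0-fold lower number from compound 1 to compound 3 (0.47 log units; beyond the scatter), and a 3.5-fold lower number from compound 1 to compound 2 (0.54 log units; beyond the scatter). Between the two longer chains, a 1.2-fold higher number from compound 2 to compound 3 (0.07 log units; within the scatter), so the gain appeared once and did not grow when vinyl was exchanged for ethyl. Pushing the chain further out is therefore expected to bring no more than a small change in this assay, if any, since the only clear gain came from the first extension. For compound 4 the expected step is a 1.3-fold lower number from compound 3 to compound 4 (0.12 log units; within the scatter). Compound 4 is estimated at 90 nM, within a range from 40 nM to 250 nM.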

Compound 4, half-maximal inhibitory concentration: 626 nM
Estimate against measurement, compound 4: 7.0-fold (0.84 log units) below; the whole stated range lies below it.
By their numbers in this assay, from the lowest: compounds 2 and 3 (each within the scatter of the next); then compounds 1 and 4 (each within the scatter of the next).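

In this assay the chain does not reward unlimited growth: ethyl in place of hydrogen on a saturated chain carbon, four bonds along the chain from a carbon with a double bond to nitrogen, gives a 5.3-fold higher number from compound 3 to compound 4 (0.72 log units; beyond the scatter) and so reverses the earlier gain. The exchange of vinyl for butyl at the position two bonds along shows the same loss, with a 6.2-fold higher number from compound 2 to compound 4 (0.79 log units; beyond the scatter) as the step, and a 1.8-fold higher number from compound 1 to compound 4 (0.25 log units; within the scatter) places the shortest and longest chains shown within the scatter of each other. No measurement available here accounts for this reversal.

Going by these compounds, whether the turn is gradual or abrupt remains open, and a pentyl chain at this place would sit in the gap. On these data alone, whether a hydroxyl group or an amine at the end of the longer chain would change the picture also remains open.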